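A few compounds are considered here, and "the series" means these few. Any claim that something is new, unique, unknown or untested is made for them only; others in the source may bear on it.

Compound 2 `COc1cccc(NC(=O)CCSc2ccc3c(/C=C/c4ccccn4)n[nH]c3c2)c1` is one of two anilides built on a shared core and tested in an ADME assay on BaF3 cells (Mus musculus) for antiproliferative activity, read by CCK-8 assay, with a stated time of 72 h (on this read-out higher numbers stand for weaker inhibition of growth and lower numbers for stronger inhibition of growth), where compound 2 gives 3840 nM. Within the data shown here, this is the lowest of the two numbers measured; its neighbour, compound 1 `O=C(CCSc1ccc2c(/C=C/c3ccccn3)n[nH]c2c1)Nc1cccc(Cl)c1`, gives 9350 nM in this assay, and the single measured step, a 2.4-fold lower number from compound 1 to compound 2 (0.39 log units; beyond the scatter), comes from a methoxy in place of chloro on an aromatic carbon. Compound 3 `Cc1ccc(NC(=O)CCSc2ccc3c(/C=C/c4ccccn4)n[nH]c3c2)cc1C(F)(F)F` has not yet been measured; it differs from compound 2 by 4-methyl-3-(trifluoromethyl)phenyl in place of 3-methoxyphenyl on an amide-type nitrogen. The step from compound 1 to compound 2 is the only one available and it concerns the same anilide ring, so an exchange there moved the number only modestly. Compound 3 is therefore expected to give a number near that of compound 2, with a step of a 1.7-fold higher number from compound 2 to compound 3 (0.23 log units; within the scatter) or none beyond the scatter. The estimate for compound 3 is 6500 nM, within a range from 2000 nM to 20000 nM.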

Compound 3, concentration for 50% growth inhibition: 530 nM
The estimate for compound 3 lay 12-fold (1.09 log units) above the measured number; measured number below the stated range.
By their numbers in this assay, from the lowest: compound 3; then compound 2; then compound 1.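

In this assay, the ring on the amide-type nitrogen turns out to hold far more room for change than the exchange of chloro for methoxy suggested, which gave only a 2.4-fold lower number from compound 1 to compound 2 (0.39 log units; beyond the scatter). With 4-methyl-3-(trifluoromethyl)phenyl in place of 3-methoxyphenyl there is a 7.2-fold lower number from compound 2 to compound 3 (0.86 log units; beyond the scatter), and with the same group in place of 3-chlorophenyl there is an 18-fold lower number from compound 1 to compound 3 (1.25 log units; beyond the scatter), so this one group sets compound 3 apart from both earlier anilides on the shared core. Nothing available here gives a reason for these steps.

Since methyl and trifluoromethyl enter together, the compounds shown cannot tell which of the two carries the step, or whether both are needed. From the compounds shown here alone, how a piperazine, a carboxylic acid or a pyridine ring in this place would stand also remains open.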